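The source may hold more compounds than are shown below. What is called first, only, known or untested is meant among the compounds shown, and "the series" means these compounds.

In an assay on HepG2 cells for agonist activity at nuclear receptor subfamily 1 group I member 3 (Homo sapiens), read by a luciferase reporter, with a stated time of 23 h (a higher number here means that more compound is needed for the effect, a lower number that less compound is needed), compound 2 `C(=N/OCc1ccccc1)\c1c(-c2ccc3ccccc3c2)nc2occn12` gives 840 nM, the lowest of the two numbers reported here. Compound 1 `COc1ccc(CO/N=C/c2c(-c3ccc4ccccc4c3)nc3occn23)cc1` gives 4400 nM, and the step of a 5.2-fold lower number from compound 1 to compound 2 (0.72 log units; beyond the scatter) comes from a single change, hydrogen in place of methoxy on an aromatic carbon. Compound 3 `C(=N/OCc1ccc(Oc2ccccc2)cc1)\c1c(-c2ccc3ccccc3c2)nc2occn12` was reported as "not active" (no number reported) in this assay, with no number attached.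

Compound 4 `C(=N/OC1Cc2ccccc2C1)\c1c(-c2ccc3ccccc3c2)nc2occn12` differs from compound 2 in one place: 2,3-dihydro-1H-inden-2-yl in place of benzyl on an oxygen. Among the compounds with values here, none of the measured steps matches this change. The step from compound 1 to compound 2 concerns a substituent on the benzyl ring, not the benzyl itself, and compound 3 only shows that a large phenoxy addition on that ring ended activity. The groups that leave and enter share one six-membered aromatic ring of carbon only, so the expected step of a 1.8-fold higher number from compound 2 to compound 4 (0.25 log units; within the scatter) is small, with wide uncertainty in either direction. Compound 4 is therefore estimated at 1500 nM, within a range from 400 nM to 6000 nM.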

Compound 4, half-maximal effective concentration: 980 nM
Compound 4: the middle estimate sits 1.5-fold (0.18 log units) above what was measured; measured number inside the range.
By their numbers in this assay, from the lowest: compounds 2 and 4 (each within the scatter of the next); then compound 1.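

In this assay, the step of a 1.2-fold higher number from compound 2 to compound 4 (0.07 log units; within the scatter) shows that this oxygen can carry 2,3-dihydro-1H-inden-2-yl in place of benzyl with no measurable change in the number. The earlier compounds shown here altered only what sat on the aromatic ring of the benzyl group, whereas this change alters the group itself by adding a five-membered non-aromatic ring. The step of a 4.5-fold lower number from compound 1 to compound 4 (0.65 log units; beyond the scatter) also places compound 4 clearly apart from the 4-methoxybenzyl compound, so the new group belongs with unsubstituted benzyl in this assay.

As far as these compounds go, whether a longer chain in place of benzyl on this oxygen would keep the number remains open. So does the effect of an amine or a carboxylic acid on the aromatic ring. No supporting measurement is available to explain these numbers.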